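The source may hold more compounds than are shown below. What is called first, only, known or untested is meant among the compounds shown, and "the series" means these compounds.

In a functional assay on MDA-MB-231 cells (Homo sapiens) for antiproliferative activity, read by MTT assay, with a stated time of 72 h (a higher number here means a weaker inhibitor, a lower number a stronger inhibitor), compound 1 `CC1=CC[C@H]2[C@H](CC[C@]2(C)O)C(C)(C)[C@@H]1CC[C@H]1[C@]2(C)CC[C@H](OCc3ccccc3)C(C)(C)O[C@H]2CC[C@@]1(C)O` gives 29100 nM, while compound 2 `CC1=CC[C@H]2[C@H](CC[C@]2(C)O)C(C)(C)[C@@H]1CC[C@H]1[C@]2(C)CC[C@H](OC(=O)c3ccc([N+](=O)[O-])cc3)C(C)(C)O[C@H]2CC[C@@]1(C)O` gives 8900 nM, the lower of the two numbers. Going by the values given here, the only measured step, a 3.3-fold lower number from compound 1 to compound 2 (0.51 log units; beyond the scatter), is modest and replaced benzyl with (4-nitrophenyl)carbonyl. Compound 3 `CC1=CC[C@H]2[C@H](CC[C@]2(C)O)C(C)(C)[C@@H]1CC[C@H]1[C@]2(C)CC[C@H](OC(=O)c3cccc(C(F)(F)F)c3)C(C)(C)O[C@H]2CC[C@@]1(C)O` has 3-(trifluoromethyl)phenyl in place of 4-nitrophenyl on a carbonyl carbon. The step to compound 2 a 3.3-fold lower number from compound 1 to compound 2 (0.51 log units; beyond the scatter) introduced the carbonyl that compound 3 keeps, and it does not test this exchange of ring substituents, so no change beyond the scatter is expected in this assay. The expected change is a 1.1-fold higher number from compound 2 to compound 3 (0.05 log units; within the scatter). For compound 3 the estimated value is 10000 nM, with an expected range of 4500 nM to 22000 nM.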

Compound 3, half-maximal inhibitory concentration: 36300 nM
Beside the measured number, compound 3's estimate is 3.6-fold (0.56 log units) below it, outside the stated range (above it).
By their numbers in this assay, from the lowest: compound 2; then compounds 1 and 3 (each within the scatter of the next).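

The result shows that in this assay the group on this carbonyl carbon matters: 3-(trifluoromethyl)phenyl in place of 4-nitrophenyl gives a 4.1-fold higher number from compound 2 to compound 3 (0.61 log units; beyond the scatter). The carbonyl alone therefore does not secure the lower number of compound 2, as (3-(trifluoromethyl)phenyl)carbonyl in place of benzyl gives only a 1.2-fold higher number from compound 1 to compound 3 (0.10 log units; within the scatter). No measurement shown here accounts for the difference between the two aryl groups. The compounds shown leave open whether the ring position or the identity of the substituent governs the step. They also leave open how a phenyl ring carrying an amine or a carboxylic acid would read at this carbonyl carbon.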